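Inverting Two Ring Stereocentres of Compound 2

The source may hold more compounds than are shown below. What is called first, only, known or untested is meant among the compounds shown, and "the series" means these compounds.

Measured so far:
Compound 1, `C=C1CCCC(C)(C)C1CC[C@]1(C)CC[C@H]([C@@H](C)C(=O)OC)OO1`, gives 2940 nM.
Compound 2, `C=C1CCCC(C)(C)C1CC[C@@]1(C)CC[C@H]([C@@H](C)C(=O)O)OO1`, gives 3350 nM.

Both values come from a functional assay on T47D cells (Homo sapiens) for inhibition; on this read-out lower numbers stand for stronger inhibition of growth and higher numbers for weaker inhibition of growth. Compound 2 has the highest of the two numbers, yet its nearest neighbour is compound 1 and that gap lies within the scatter, so no order between them is claimed. Compound 3, `C=C1CCCC(C)(C)C1CC[C@]1(C)CC[C@@H]([C@@H](C)C(=O)O)OO1`, keeps every atom and bond of compound 2; the change is the two compounds have the same atoms and bonds; at least one stereo element is drawn with a configuration in one of them and without one in the other: 2 of 4 stereo elements differ; a stereocentre at a saturated ring carbon is drawn S in compound 2 and R in compound 3; a stereocentre at a saturated ring carbon is drawn R in compound 2 and S in compound 3. For the measured compounds named here, no measured pair here reports such a change, so its size cannot be read from data. Compound 3 is expected to land near compound 2, with a step of a 1.0-fold higher number from compound 2 to compound 3 (0.02 log units; within the scatter), giving an estimate of 3500 nM, between 1200 nM and 10000 nM.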

Compound 3, concentration for 50% growth inhibition: > 10000 nM
Compound 3: only a limit was reported; the forecaster's own chance of this, stated with the estimate: 5%; middle value at least 2.8-fold (0.45 log units) from the limit.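

In this assay, the arrangement at these two saturated ring carbons clearly matters: with the same atoms and bonds, the change gives an at least 2.9-fold higher number from compound 2 to compound 3 (0.47 log units; beyond the scatter). The true size of this step cannot be read, as compound 3 gives > 10000 nM, which is a limit and not a number: the limit of > 10000 nM in this assay, at which 1 of the 3 values shown sits. The comparison also carries this caution: the fact that one of compounds 2 and 3 is drawn with a defined configuration and the other without, at the place where they differ.

Which of the two stereocentres accounts for the weaker growth inhibition remains open. So does whether an amide in place of the carboxylic acid would respond in the same way.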